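This account rests on a few compounds, and the source may have more. Where it says the series, first, only, none or still open, it means among the compounds named here.

Compound 2 `CN(C(=O)N1CC[C@H](n2cnc3cc(-c4ccc(Cl)cc4)sc3c2=O)C1)[C@H]1CCN(CC2CC2)C1` carries a cyclopropylmethyl group on the ring amine nitrogen and gives 3 nM in an assay on isolated protein for binding affinity to melanin-concentrating hormone receptor 1 (Homo sapiens); a lower number here means a stronger inhibitor, a higher number a weaker inhibitor. On the two numbers available it stands highest, and its nearest neighbour is compound 1 `CN(C(=O)N1CC[C@H](n2cnc3cc(-c4ccc(Cl)cc4)sc3c2=O)C1)[C@H]1CCN(C2CCC(C)(C)CC2)C1`, which gives 2 nM in this assay. For the measured compounds named here, the only measured step, 4,4-dimethylcyclohexyl replaced by cyclopropylmethyl on the amine nitrogen in the ring, a 1.5-fold higher number from compound 1 to compound 2 (0.18 log units; within the scatter), so the two substituents on that nitrogen are read as equivalent within the noise.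

Compound 3 `CN(C(=O)N1CC[C@H](n2cnc3cc(-c4ccc(Cl)cc4)sc3c2=O)C1)[C@H]1CCN(CC2CCCCC2)C1` differs from compound 2 by cyclohexyl in place of cyclopropyl on a saturated chain carbon bound to an amine nitrogen in a ring. Going by the values given here, the only step that bears on this change is the one from compound 1 to compound 2, and it was within the scatter; a cyclohexyl group already sits on that nitrogen in compound 1 with no penalty. No step beyond the scatter is therefore expected in this assay, a 1.2-fold lower number from compound 2 to compound 3 (0.08 log units; within the scatter). Compound 3 is estimated at 2.5 nM in this assay, with an expected range of 0.8 nM to 8 nM.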

Compound 3, inhibition constant: 50 nM
Compound 3: the middle estimate sits 20-fold (1.30 log units) below what was measured; measured number outside the range, above it.
By their numbers in this assay, from the lowest: compounds 1 and 2 (each within the scatter of the next); then compound 3.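

In this assay, the group on the amine nitrogen in the ring proves not to be freely interchangeable: cyclohexyl in place of cyclopropyl on the saturated chain carbon gives a 17-fold higher number from compound 2 to compound 3 (1.22 log units; beyond the scatter) and so separates two groups that differ only in that ring. A six-membered ring of carbon only is not penalised as such at this nitrogen, since cyclohexylmethyl compared with 4,4-dimethylcyclohexyl gives a 25-fold higher number from compound 1 to compound 3 (1.40 log units; beyond the scatter) and the outcome therefore depends on the whole group rather than on the presence of that ring. No measurement at hand accounts for this loss.

Open, as far as these compounds go, is where the fall sets in between cyclopropylmethyl and cyclohexylmethyl, which cyclobutylmethyl and cyclopentylmethyl would help to locate, and whether unsubstituted cyclohexyl set directly on the nitrogen would read with compound 1 or with compound 3. Also open, from the compounds shown here alone, is whether a ring carrying a heteroatom, such as tetrahydropyran-4-ylmethyl, or an open chain such as isobutyl would behave like cyclopropylmethyl or like cyclohexylmethyl at this nitrogen.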